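Carbamate change on a selenocyanate: small step expected

The source may report more compounds than this note shows. Statements on the series, on what has been measured and on what is new or still open speak of the compounds shown alone.

Of the compounds shown here, three have been measured in a physicochemical assay, with a stated time of 180 min, tested at 0.5 mg/mL; a higher number here means more inhibition at the concentration tested (going by the name of the read-out), a lower number less inhibition. Compound 1 `CC(C)COC(=O)Nc1ccc([Se][Se]c2ccc(NC(=O)OCC(C)C)cc2)cc1` gives 66.5%, and compound 3 `O=C(Nc1ccc([Se][Se]c2ccc(NC(=O)Oc3ccccc3)cc2)cc1)Oc1ccccc1` gives 66.9%; these two share a paired, selenium-linked build and their numbers lie within the usual scatter of each other. Compound 2 `CCCCOC(=O)Nc1ccc([Se]C#N)cc1` is built as a single half and gives 6.6%, the lowest of the three numbers, with both compound 1 and compound 3 sitting well beyond the scatter above it.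

Compound 4 `N#C[Se]c1ccc(NC(=O)OCc2ccccc2)cc1` keeps the single-half build of compound 2 and changes only the carbamate ester: phenyl in place of propyl on a saturated chain carbon bound to an oxygen next to a carbonyl group.

Among the measured compounds, the ester end varies between compound 1 and compound 3 without a difference beyond the scatter, so the step from compound 2 to compound 4 is expected to be small, with no direction beyond the scatter, as an expected change of a number 3.4 percentage points higher from compound 2 to compound 4 (within the scatter). In this assay compound 4 is therefore estimated to give 10%, within a range from 0% to 30%.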

Compound 4, a percentage reported as inhibition, at one concentration (the size of the read-out at that concentration, not a potency): 3.7%
Compound 4: middle estimate off by 6.3 percentage points, on the high side; the measured number falls inside the stated range.
By their numbers in this assay, from the lowest: compounds 4 and 2 (each within the scatter of the next); then compounds 1 and 3 (each within the scatter of the next).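

In this assay, phenyl in place of propyl on a saturated chain carbon bound to an oxygen next to a carbonyl group gives a number 2.9 percentage points lower from compound 2 to compound 4 (within the scatter) and is the only one-place comparison among these compounds. On the single-half build, this position therefore accepts a six-membered aromatic ring in place of a short chain with no change beyond the scatter, and the swap alone does not lift the number towards those of the paired compounds. Nothing measured here explains this result.

As far as these compounds go, whether an amine or a carboxylic acid at this end of the carbamate would shift the number remains open. So does whether the same swap would behave alike on the paired, selenium-linked build.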